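The compounds below may be only part of what the source reports. "The series", "measured", "known", "first", "only" and "open" are said of these compounds alone.

Compound 2 `CCOC(=O)/C(O)=C/C(=O)c1cn(Cc2ccc(F)c(F)c2)c2cccc(OC)c12` carries the ethyl ester. Within the data shown here, in an ADME assay on MT4 cells (Homo sapiens) for cytotoxicity, read by MTT assay (on this read-out higher numbers stand for lower toxicity in this test and lower numbers for higher toxicity in this test), compound 2 gives 125000 nM, the top number of the three so far; compound 1 `COc1cccc2c1c(C(=O)/C=C(\O)C(=O)O)cn2Cc1ccc(F)c(F)c1` gives 71000 nM, and the step of a 1.8-fold higher number from compound 1 to compound 2 (0.25 log units; within the scatter) stays within the scatter, while compound 3 `COc1cccc2c1c(C(=O)/C=C(\O)C(=O)O)cn2Cc1ccc(F)c(F)c1F` gives 22800 nM. The change to compound 4 `CCOC(=O)/C(O)=C/C(=O)c1cn(Cc2c(F)cccc2F)c2cccc(OC)c12` is 2,6-difluorophenyl in place of 3,4-difluorophenyl on a saturated chain carbon bound to an aromatic nitrogen. Among the measured compounds shown here, no measured step rearranges fluorines; the only step involving fluorine, a 3.1-fold lower number from compound 1 to compound 3 (0.49 log units; beyond the scatter), added a fluoro and lowered the number modestly, and the ester step stayed within the scatter. With the same atoms merely rearranged, the expected step is a 1.4-fold lower number from compound 2 to compound 4 (0.14 log units; within the scatter), within the scatter, leaning if anything toward a lower number. Compound 4 is therefore estimated at 90000 nM in this assay, with a range of 30000 nM to 250000 nM.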

Compound 4, half-maximal cytotoxic concentration: 63400 nM
Beside the measured number, compound 4's estimate is 1.4-fold (0.15 log units) above it; the measured number falls inside the stated range.
By their numbers in this assay, from the lowest: compound 3; then compounds 4, 1 and 2 (each within the scatter of the next).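

Exchanging 3,4-difluorophenyl for 2,6-difluorophenyl on a saturated chain carbon bound to an aromatic nitrogen gives a 2.0-fold lower number from compound 2 to compound 4 (0.29 log units; within the scatter) in this assay. Among these compounds, this is the first measured rearrangement of fluorines at this position, and with the same atoms present, it does not separate the two ethyl esters beyond the scatter. Nothing available accounts for this step. Open, from the compounds shown here alone, is whether the same rearrangement stays within the scatter for the free acids. Also open, going by these compounds, is how an unsubstituted phenyl or a 2,6-dichlorophenyl would read at this position.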